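This account rests on a few compounds, and the source may have more. Where it says the series, first, only, none or still open, it means among the compounds named here.

Compound 1, `Cc1cc(NC(=O)Cn2nnc(-c3ccccc3)n2)n(C2CCC(C)(C)CC2)n1`. In an assay on HEK293 cells for activation of Kir3.1/Kir3.2 (Homo sapiens), read by thallium flux (a higher number here means that more compound is needed for the effect, a lower number that less compound is needed), compound 1 gives > 221 nM, which is a limit of the assay and not a number.
Compound 2, `Cc1cc(NC(=O)Cn2nnc(-c3ccccc3)n2)n(C(C)C)n1`. In this assay compound 2 gives 556 nM.
Compound 3, `Cc1cc(NC(=O)Cn2nnc(-c3ccccc3)n2)n(C2CCCC2)n1`, not yet measured.

Within the data shown here, compound 2 holds the only number among the two values shown; the other value is a limit. Among the measured compounds shown here, the one measured step, a step that the limit leaves unreadable from compound 1 to compound 2, cannot be read in size or direction because the limit of > 221 nM in this assay, at which 1 of the 2 values shown sits, sits on one side of it. The change to compound 3 is cyclopentyl in place of isopropyl on an aromatic nitrogen. The cyclopentyl group falls between the isopropyl of compound 2 and the 4,4-dimethylcyclohexyl of compound 1 in its count of carbon atoms, but no readable step tells how such a change moves this assay. The expectation for compound 3 is therefore a step of a 1.4-fold higher number from compound 2 to compound 3 (0.16 log units; within the scatter) that stays within the scatter, with a wide range and a real chance of a limit again. Compound 3 is estimated at 800 nM, between 250 nM and 3000 nM.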

Compound 3, half-maximal effective concentration: 163 nM
The estimate for compound 3 lay 4.9-fold (0.69 log units) above the measured number; measured number below the stated range.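

In this assay, among these compounds, cyclopentyl on the aromatic nitrogen in place of isopropyl gives the first step at this position that can be read: a 3.4-fold lower number from compound 2 to compound 3 (0.53 log units; beyond the scatter). This shows that the number responds to the group at this place, and that, for this pair, the five-membered ring of carbon needs less compound than the open isopropyl. The other new step is an at least 1.3-fold lower number from compound 1 to compound 3 (0.13 log units; that floor lies within the scatter), a floor that sets no order between the cyclopentyl and 4,4-dimethylcyclohexyl groups, and the remaining step cannot be read: the limit of > 221 nM in this assay, at which 1 of the 3 values shown sits.

Going by these compounds, it remains open whether a plain cyclohexyl, a cyclobutyl ring or a longer chain such as butyl on this nitrogen would lower the number further. On these data alone, it is also open how a ring carrying oxygen, such as tetrahydropyranyl, or an amine would read at this place.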